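This account rests on a few compounds, and the source may have more. Where it says the series, first, only, none or still open, it means among the compounds named here.

Compound 1, `Cc1ccnc(/C(N)=N/NC(=S)N2CCCC2)c1`, is the reference point of this account. Among the compounds with values here, in a functional assay on MCF7 cells (Homo sapiens) for cytotoxicity, read by MTT assay, with a stated time of 72 h, tested at 1 uM (on this read-out lower numbers stand for less inhibition of growth and higher numbers for more inhibition of growth at the one concentration tested), compound 1 gives 49%, the highest of the three numbers measured so far. Compound 2, `Cc1ccnc(/C(N)=N/NC(=S)N2CCCCCC2)c1`, gives 18.2% in this assay, a figure that lies beyond the scatter below that of compound 1. Compound 3, `N/C(=N\NC(=S)N1CCN(c2ccccn2)CC1)c1ccc(F)cn1`, gives 13.4% in this assay, the furthest from compound 1 and again beyond the scatter. The unmeasured compound 4, `Cc1ccnc(/C(N)=N/NC(=S)N2CCOCC2)c1`, differs from compound 1 in a single place: morpholin-4-yl in place of pyrrolidin-1-yl on a thiocarbonyl carbon. Within the data shown here, no step between two measured compounds matches this change, so the expectation rests only on the spread of the measured numbers. A downward step is expected, of moderate size, because compound 2 in this assay already gives 18.2% while carrying the same core. The step from compound 1 to compound 4 is therefore estimated at a number 19 percentage points lower from compound 1 to compound 4 (beyond the scatter). For compound 4 in this assay the estimated value is 30%, within a range from 15% to 45%.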

Compound 4, percent growth inhibition at one concentration: 1.22%
Compound 4: the middle estimate sits 28.8 percentage points above what was measured, outside the stated range (below it).
By their numbers in this assay, from the lowest: compound 4; then compounds 3 and 2 (each within the scatter of the next); then compound 1.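

In this assay, within the data shown here, the exchange of pyrrolidin-1-yl for morpholin-4-yl on a thiocarbonyl carbon gives a number 47.8 percentage points lower from compound 1 to compound 4 (beyond the scatter) and is the first step that can be read between two measured compounds differing in one place. It shows that, with the rest of compound 1 unchanged, the group at this place alone can take growth inhibition at the one concentration tested almost entirely away, leaving compound 4 at 1.22% in this read-out. Nothing at hand explains this step. The compounds shown leave open how much of the step goes with the ring oxygen and how much with the six-membered ring, which a piperidin-1-yl group at this place would separate. Also open, on these data alone, is how an open-chain dimethylamino group at this place would compare with either ring.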